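The source may report more compounds than this note shows. Statements on the series, on what has been measured and on what is new or still open speak of the compounds shown alone.

Measured in a functional assay on MCF7 cells (Homo sapiens) for antiproliferative activity, read by MTT assay, with a stated time of 48 h; a lower number here means a stronger inhibitor, a higher number a weaker inhibitor:
compound 1, `COc1cc2c(Nc3ccc(NC(=O)Nc4ccccc4)cc3)ncnc2cc1OCc1ccccc1`, gives 22800 nM
compound 2, `COc1cc2c(Nc3ccc(NC(=O)Nc4ccccc4)cc3)ncnc2cc1OCCCN1CCN(C)CC1`, gives 29100 nM

Within the data shown here, compound 2 carries the larger of the two numbers in this assay, but its only neighbour is compound 1, and the gap between them is a 1.3-fold higher number from compound 1 to compound 2 (0.11 log units; within the scatter), so the two cannot be told apart on these data. That single step concerns the chain on the oxygen of the shared core and is the whole of what has been measured.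

Compound 3, `COc1cc2c(Nc3ccc(NC(=O)Nc4ccccc4)c(Cl)c3)ncnc2cc1OCCCN1CCN(C)CC1`, differs from compound 2 in another place: chloro in place of hydrogen on an aromatic carbon. Among the measured compounds shown here, no measured pair touches that ring position, so there is nothing here to point in either direction. For the measured compounds named here, the one known step, a 1.3-fold higher number from compound 1 to compound 2 (0.11 log units; within the scatter), stayed within the scatter even for a sizeable change elsewhere, and the two measured values sit close together in this assay.

On that basis compound 3 is expected to stay near compound 2, with a step of a 1.2-fold lower number from compound 2 to compound 3 (0.07 log units; within the scatter), which is no change beyond the scatter. The estimate for compound 3 in this assay is 25000 nM, within 10000 nM to 60000 nM.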

Compound 3, half-maximal inhibitory concentration: > 50000 nM
Compound 3: only a limit was reported; the forecaster's own chance of this, stated with the estimate: 10%; middle value at least 2.0-fold (0.30 log units) away from the limit.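

In this assay, on these data alone, compound 3 is reported only as a limit, > 50000 nM, and its actual number stays unknown. With chloro in place of hydrogen on an aromatic carbon ortho to a (phenylcarbamoyl)amino group, the result is an at least 1.7-fold higher number from compound 2 to compound 3 (0.23 log units; that floor lies within the scatter); this is a floor and not a measured size, so the change cannot be called a loss beyond the scatter, although the real step may be larger. The earlier pair never touched this ring, and the new result adds one thing about it: chloro at this place brings no lower number, and the reading for the new compound ends at a limit: the limit of > 50000 nM in this assay, at which 1 of the 3 values shown sits.

As far as these compounds go, how far the number actually rises with chloro remains open, as does whether a smaller or different group on the same aromatic carbon, such as fluoro, methyl or methoxy, would leave the number where it stands or lower it. From the compounds shown here alone, it is also open whether chloro at this place would give the same outcome with the benzyl group of compound 1 on the oxygen of the shared core in place of the piperazine chain.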